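Swapping the Thiazole for a Methyloxazole on the Core

The source may hold more compounds than are shown below. What is called first, only, known or untested is meant among the compounds shown, and "the series" means these compounds.

In a physicochemical assay for solubility (on this read-out lower numbers stand for lower solubility and higher numbers for higher solubility), compound 3 `O=S(=O)(Nc1nccs1)c1ccc2c(c1)OCC[C@@H]2c1ccc(C(F)(F)F)cc1-c1nccs1` gives 15000 nM, the second highest of the three numbers measured. Its nearest neighbour is compound 1 `O=S(=O)(Nc1nccs1)c1ccc2c(c1)OCC[C@@H]2c1ccc(C(F)(F)F)cc1-c1ccc(F)cn1`, which in this assay gives 7000 nM; the furthest is compound 2 `Cc1nc(-c2cc(C(F)(F)F)ccc2[C@@H]2CCOc3cc(S(=O)(=O)Nc4nccs4)ccc32)co1`, which gives 130000 nM. Compound 4 `Cc1nc(-c2cc(C(F)(F)F)ccc2[C@H]2CCOc3cc(S(=O)(=O)Nc4nccs4)ccc32)co1` has not yet been measured. It differs from compound 3 in one place: 2-methyl-1,3-oxazol-4-yl in place of 1,3-thiazol-2-yl on an aromatic carbon.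

Within the data shown here, only one measured step stands in the same region of the core: a 2.1-fold higher number from compound 1 to compound 3 (0.33 log units; beyond the scatter). That step exchanged one five-membered aromatic ring for another on the same aromatic carbon and moved the number modestly. The change to compound 4 is of the same type, and compound 2 bears the very group that enters, 2-methyl-1,3-oxazol-4-yl, with a much higher number than compound 3.

The expected step is therefore upward and clearly beyond the scatter: a 7.3-fold higher number from compound 3 to compound 4 (0.87 log units; beyond the scatter) is estimated. Compound 4 is expected to give 110000 nM, with a likely range from 45000 nM to 280000 nM, because compound 2 with the same group gives 130000 nM.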

Compound 4, solubility: 61000 nM
Compound 4: the middle estimate sits 1.8-fold (0.26 log units) above what was measured; the measured number falls inside the stated range.
By their numbers in this assay, from the lowest: compound 1; then compound 3; then compound 4; then compound 2.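

In this assay, 2-methyl-1,3-oxazol-4-yl on this aromatic carbon, ortho to a large group and meta to a trifluoromethyl group, gives a higher number than either earlier group: replacing 1,3-thiazol-2-yl gives a 4.1-fold higher number from compound 3 to compound 4 (0.61 log units; beyond the scatter) and replacing 5-fluoropyridin-2-yl gives an 8.7-fold higher number from compound 1 to compound 4 (0.94 log units; beyond the scatter). The earlier compounds shown here offered no direct reading of this group against either of the others with the stereocentre drawn the same way, and they offered no pair that separated the group from the configuration. That pair now exists, and a 2.1-fold lower number from compound 2 to compound 4 (0.33 log units; beyond the scatter) can be assigned to the stereocentre alone because of one structural fact: the fact that compounds 2 and 4 differ only in the configuration as drawn.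

These compounds leave open whether reversing the configuration would move the number in the same direction with 1,3-thiazol-2-yl or 5-fluoropyridin-2-yl at this carbon, so the gap is known for a single group only. They also leave open how an amine, a carboxylic acid or a longer chain at the same carbon would read in this assay.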